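The source may hold more compounds than are shown below. What is called first, only, known or untested is meant among the compounds shown, and "the series" means these compounds.

Compound 1 `C=C(Cl)C(=O)Nc1cc(Nc2nccc(-c3cn(C)c4ccccc34)n2)c(OC)cc1N(C)CCN(C)C` sets the reference: in a functional assay on HepG2 cells (Homo sapiens) for antiproliferative activity, read by MTT assay, with a stated time of 72 h (on this read-out lower numbers stand for stronger inhibition and higher numbers for weaker inhibition), compound 1 gives 1390 nM. Compound 2 `CC/C=C\C(=O)Nc1cc(Nc2nccc(-c3cn(C)c4ccccc34)n2)c(OC)cc1N(C)CCN(C)C` gives 6670 nM, the highest number of the three, and so the weakest inhibitor here; compound 3 `CC/C=C\C(=O)Nc1cc(Nc2ncc(C#N)c(-c3cn(C)c4ccccc34)n2)c(OC)cc1N(C)CCN(C)C` gives 1360 nM. Two measured steps frame this: a 4.8-fold higher number from compound 1 to compound 2 (0.68 log units; beyond the scatter) and a 4.9-fold lower number from compound 2 to compound 3 (0.69 log units; beyond the scatter). Compound 4 `CC/C=C\C(=O)Nc1cc(Nc2nc(C)cc(-c3cn(C)c4ccccc34)n2)c(OC)cc1N(C)CCN(C)C` differs from compound 2 by methyl in place of hydrogen on an aromatic carbon, placed next to the ring nitrogen. Only the step to compound 3 changes the same ring, and it used a different group at a different carbon, so it offers weak guidance; the methyl is small, and no listed step tests it. A step within or just beyond the scatter is expected, direction uncertain, with a 1.3-fold lower number from compound 2 to compound 4 (0.13 log units; within the scatter). Compound 4 is therefore estimated at 5000 nM, between 1500 nM and 16000 nM.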

Compound 4, half-maximal inhibitory concentration: 2050 nM
Compound 4: the middle estimate sits 2.4-fold (0.39 log units) above what was measured, within the range that was stated.
By their numbers in this assay, from the lowest: compounds 3, 1 and 4 (each within the scatter of the next); then compound 2.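

In this assay a methyl on the aromatic carbon next to the ring nitrogen gives a 3.3-fold lower number from compound 2 to compound 4 (0.51 log units; beyond the scatter) and so shows that this position, untested until now, is not indifferent to even a small group. Among these compounds, on this ring, the only earlier change was a cyano group at a different carbon. Nothing measured here explains the change.

Still open, on these data alone, is whether an ethyl, a methoxy or an amine at this same carbon would lower the number further. Also open, as far as these compounds go, is whether the methyl would act alike with the 1-chloroethenyl group of compound 1 in place of but-1-en-1-yl.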